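Swapping cyclopropyl for cyclopentyl on the shared core

The source may report more compounds than this note shows. Statements on the series, on what has been measured and on what is new or still open speak of the compounds shown alone.

Compound 1 (`OC[C@H]1O[C@@H](n2cnc3c(NC4CCCC4)nc(NC4CCCCCC4)nc32)[C@H](O)[C@@H]1O`) gives 167000 nM
Compound 2 (`OC[C@H]1O[C@@H](n2cnc3c(NC4CC4)nc(NC4CC4)nc32)[C@H](O)[C@@H]1O`) gives "not determined" (no result reported)

In an ADME assay on HEK-293T cells (Homo sapiens) for cytotoxicity, read by resazurin assay, with a stated time of 16 h (a higher number here means a weaker inhibitor, a lower number a stronger inhibitor), compound 2 is recorded as "not determined" (no result reported) and so has no place on the scale. Compound 3 (`OC[C@H]1O[C@@H](n2cnc3c(NC4CCCC4)nc(NC4CC4)nc32)[C@H](O)[C@@H]1O`) comes from compound 2 by putting cyclopentyl in place of cyclopropyl on a nitrogen on an aromatic ring. With no number for compound 2, the size of this step cannot be read from it. Compound 1 at 167000 nM is the only measured anchor, so no shift beyond the usual scatter from that value, in either direction, is expected in this assay. For compound 3 the expected value is 200000 nM (estimated range 80000 nM to 500000 nM).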

Compound 3, half-maximal inhibitory concentration: > 500000 nM
Compound 3: a limit, no number; the forecaster's own chance of this, stated with the estimate: 40%; at least 2.5-fold (0.39 log units) between middle value and limit.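

In this assay, compound 3 gives > 500000 nM, which is a limit of the assay and not a number. For the compounds shown here, it still provides the first readable step: cyclopropyl in place of cycloheptyl on a nitrogen on an aromatic ring goes with an at least 2.9-fold higher number from compound 1 to compound 3 (0.47 log units; beyond the scatter). The full size of this step stays unknown because the reading stops at a limit: the limit of > 500000 nM in this assay, at which 1 of the 3 values shown sits.

The step from compound 2 to compound 3 cannot be read. From the compounds shown here alone, it remains open whether a cyclobutyl or cyclohexyl ring, or an open chain carrying an amine, on this nitrogen would give a value within the range of this assay.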